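The compounds below may be only part of what the source reports. "The series", "measured", "known", "first", "only" and "open" are said of these compounds alone.

Measured compounds:
Compound 1 `C=C[C@@](C)(/C=C/c1ccc(OS(=O)(=O)C(F)(F)F)cc1)CCC=C(C)C`: in a functional assay on SEM cells (Homo sapiens) for cytotoxicity, with a stated time of 72 h (a lower number here means that less compound is needed, a higher number that more compound is needed for the effect), compound 1 gives > 36600 nM, which is a limit of the assay and not a number.
Compound 2 `C=C[C@@](C)(/C=C/c1ccc(OS(=O)(=O)c2ccc(C)cc2)cc1)CCC=C(C)C`: in this assay compound 2 gives > 43400 nM, also a limit.
Compound 3 `C=C[C@@](C)(/C=C/c1ccc(O)c(/C=C/C(=O)O)c1)CCC=C(C)C`: in this assay compound 3 gives > 36600 nM, also a limit.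

Compound 1 therefore stands only at a limit, as do both other measured compounds, see the limit of > 36600 nM in this assay, at which 2 of the 3 values shown sit, and (the limit of > 43400 nM in this assay, at which 1 of the 3 values shown sits). Among the compounds with values here, the single step between measured compounds, a step that the two limits leave unreadable from compound 1 to compound 2, cannot be read. Compound 4 `C=C[C@@](C)(/C=C/c1ccc(-c2ccc(Cl)c(Cl)c2)cc1)CCC=C(C)C` differs from compound 1 by 3,4-dichlorophenyl in place of ((trifluoromethyl)sulfonyl)oxy on an aromatic carbon. Within the data shown here, no measured step bears on this change, since the only one available lies between two limits and has no size. The expectation for compound 4 in this assay is thus a value near the limit, estimated at 30000 nM with a range of 8000 nM to 100000 nM. This estimate means an expected step of an at least 1.2-fold lower number from compound 1 to compound 4 (0.08 log units; that floor lies within the scatter), with no readable direction.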

Compound 4, half-maximal effective concentration: > 36600 nM
Compound 4 gave a limit, no number; the forecaster's own chance of this, stated with the estimate: 60%; middle value at least 1.2-fold (0.08 log units) away from the limit.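

Compound 4, like compound 1, gives only a limit, so the step between these two compounds cannot be read. The compounds shown leave open which change to the shared core, if any, gives a number in this assay rather than a limit.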